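Adding a Second Chloro to a Urea Chromone

The compounds below may be only part of what the source reports. "The series", "measured", "known", "first", "only" and "open" are said of these compounds alone.

Measured so far:
Compound 1, `O=C(Nc1cccc(Cl)c1)Nc1ccc(-c2cc(=O)c3ccccc3o2)c(Cl)c1`, 26.8%
Compound 2, `COc1ccc2oc(-c3ccc(NC(=O)Nc4cccc(Cl)c4)cc3Cl)cc(=O)c2c1`, 35.7%

Both compounds were tested in an ADME assay on L02 cells (Homo sapiens) for inhibition, read by MTT assay, with a stated time of 48 h, tested at 50 uM; a higher number here means a stronger effect of the compound at the concentration tested, a lower number a weaker effect. Among the measured compounds shown here, the only step among them, a number 8.9 percentage points higher from compound 1 to compound 2 (within the scatter), is within the scatter, so compound 2 stands at a number that cannot be told apart from that of compound 1 on these data.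

Compound 3, `COc1ccc2oc(-c3ccc(NC(=O)Nc4ccc(Cl)c(Cl)c4)cc3Cl)cc(=O)c2c1`, has not yet been measured. It differs from compound 2 in one place: chloro in place of hydrogen on an aromatic carbon. For the measured compounds named here, no measured step involves a chloro group entering or leaving, so the single known step, a methoxy in place of hydrogen, does not bear on this change. There is therefore no basis in these data for expecting a shift beyond the scatter in this assay.

Compound 3 is estimated to give 37%, between 20% and 55%. This estimate means a step of a number 1.3 percentage points higher from compound 2 to compound 3 (within the scatter), no larger than the scatter.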

Compound 3, a percentage reported as inhibition, at one concentration (the size of the read-out at that concentration, not a potency): 66.4%
Compound 3: the middle estimate sits 29.4 percentage points below what was measured; measured number above the stated range.
By their numbers in this assay, from the lowest: compounds 1 and 2 (each within the scatter of the next); then compound 3.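

In this assay, changing 3-chlorophenyl to 3,4-dichlorophenyl gives a number 30.7 percentage points higher from compound 2 to compound 3 (beyond the scatter), so a single added chloro group at this position moves the read-out clearly at the concentration tested. Among the compounds shown here, the earlier methoxy change gave only a number 8.9 percentage points higher from compound 1 to compound 2 (within the scatter), so this is the first change here that can be told apart from ordinary variation, and it shows that this aromatic carbon, ortho to a chloro group and para to a large group, is a place where one added atom can matter. No measurement shown here explains the size of this step.

On these data alone, it remains open whether another group at this position, such as fluoro, methyl or an amine, would give a similar step. As far as these compounds go, it is also open whether the added chloro group would have the same effect on the core of compound 1, which lacks the methoxy group.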